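This account rests on a few compounds, and the source may have more. Where it says the series, first, only, none or still open, it means among the compounds named here.

Compound 1 is `CCOC(=O)C(=O)CC(=O)/C=C/c1cn(C=C(C)C)c2ccccc12`; in an assay on isolated protein for inhibition of DNA nucleotidylexotransferase (Homo sapiens), read by scintillation counting, with a stated time of 10 min (on this read-out higher numbers stand for weaker inhibition and lower numbers for stronger inhibition), compound 1 gives > 40 uM, which is a limit of the assay, not a number. Compound 2 is `C=C(C)Cn1cc(/C=C/C(=O)CC(=O)C(=O)OCC)c2ccccc21`; compound 2 gives > 40 uM, again only a limit. Compound 3 is `CCOC(=O)C(=O)CC(=O)/C=C/c1cn(Cc2ccc(F)cc2)c2ccccc12`; compound 3 gives > 40 uM, likewise a limit.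

Compound 3 therefore stands where every measured compound stands, at the limit of > 40 uM in this assay, at which 3 of the 3 values shown sit. Compound 4, `CCOC(=O)C(=O)CC(=O)/C=C/c1cn(Cc2ccc(C#N)cc2)c2ccccc12`, differs from compound 3 by cyano in place of fluoro on an aromatic carbon. The measured steps a step that the two limits leave unreadable from compound 1 to compound 2, a step that the two limits leave unreadable from compound 1 to compound 3 and a step that the two limits leave unreadable from compound 2 to compound 3 all change the group on the aromatic nitrogen, and none has a readable size since all three values sit at the limit of > 40 uM in this assay, at which 3 of the 3 values shown sit. Among the compounds with values here, no measured step bears on a cyano for fluoro exchange. The expected step from compound 3 to compound 4 in this assay is a number no higher from compound 3 to compound 4 (the limit leaves the size open), with compound 4 expected to remain at the limit. Compound 4 is estimated at 40 uM in this assay, within 20 uM to 200 uM.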

Compound 4, concentration for 50% inhibition: > 40 uM
Compound 4 was reported as a limit; the forecaster's own chance of this, stated with the estimate: 85%; the middle value lies on the limit itself.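

The steps from compound 1, compound 2 and compound 3 to compound 4 cannot be read, since all four compounds sit at one limit: the limit of > 40 uM in this assay, at which 4 of the 4 values shown sit. The compounds shown leave open how strongly any of them inhibits in this assay, and whether any group on the aromatic nitrogen changes that.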